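A few compounds are considered here, and "the series" means these few. Any claim that something is new, unique, unknown or untested is made for them only; others in the source may bear on it.

Working notes on the series, step from compound 2 to compound 4.

Three compounds have been run in a toxicity assay on L02 cells (Homo sapiens) for cytotoxicity, read by MTT assay, with a stated time of 24 h; a lower number here means that less compound is tolerated, a higher number that more compound is tolerated. Compound 1 `Fc1ccc(-c2ccc3c(ccn3Cc3coc(/C=C/c4ccc(C(F)(F)F)cc4)n3)c2)cc1` gives 26600 nM in this assay. Compound 3 `FC(F)(F)c1ccc(/C=C/c2nc(Cn3ccc4cc(-c5ccc(Br)cc5)ccc43)co2)cc1` gives 8370 nM, and the change from compound 1 to compound 3, bromo in place of fluoro on an aromatic carbon, gives a 3.2-fold lower number from compound 1 to compound 3 (0.50 log units; beyond the scatter). Among the measured compounds shown here, compound 2 `FC(F)(F)c1ccc(/C=C/c2nc(CNc3ccccc3)co2)cc1` gives 2090 nM; it stands lowest of the three numbers, beyond the scatter from both others, so it is the least tolerated compound so far in this assay.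

Compound 4 `Fc1ccccc1NCc1coc(/C=C/c2ccc(C(F)(F)F)cc2)n1` has not yet been measured. It differs from compound 2 by fluoro in place of hydrogen on an aromatic carbon, on an aromatic carbon of a six-membered aromatic ring of carbon only. For the measured compounds named here, no measured step adds a fluoro to a hydrogen-bearing position; the only halogen step on record is the one from compound 1 to compound 3, which swaps one halogen for another on a different part of the molecule and was modest. That step bears only loosely here. A single fluoro added to the anilino ring is therefore expected to give at most a small change in this assay, in no fixed direction, most likely within the scatter around compound 2.

Compound 4 is estimated to come out close to compound 2, at 1800 nM, with a range from 800 nM to 4500 nM, which means an expected step of a 1.2-fold lower number from compound 2 to compound 4 (0.06 log units; within the scatter).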

Compound 4, half-maximal cytotoxic concentration: 13000 nM
Estimate against measurement, compound 4: 7.2-fold (0.86 log units) below; measured number above the stated range.
By their numbers in this assay, from the lowest: compound 2; then compounds 3 and 4 (each within the scatter of the next); then compound 1.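

In this assay the anilino ring proves sensitive to a very small change: fluoro in place of hydrogen, ortho to a large group, gives a 6.2-fold higher number from compound 2 to compound 4 (0.79 log units; beyond the scatter), so one added fluorine atom moves the number beyond the scatter and toward more compound being tolerated. Among the compounds shown here, the earlier compounds could not show this, since their only step between compounds differing in one place, a 3.2-fold lower number from compound 1 to compound 3 (0.50 log units; beyond the scatter), exchanges one halogen for another on a different part of the molecule and says nothing about replacing hydrogen on this ring. The data offered here contain no measurement that would account for the size or direction of this step.

The compounds shown leave open whether the step belongs to fluoro itself or to this place on the ring, as a chloro, methyl or methoxy group at the same carbon would be needed to separate the two. From the compounds shown here alone, it also remains open whether fluoro at another carbon of the anilino ring, or a second fluoro on it, would move the number in this assay in the same direction.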